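The source may report more compounds than this note shows. Statements on the series, on what has been measured and on what is new or still open speak of the compounds shown alone.

In an assay on isolated protein for inhibition of DNA topoisomerase 1 (Homo sapiens), with a stated time of 15 min (a lower number here means a stronger inhibitor, a higher number a weaker inhibitor), the compounds measured so far gave:

compound 1 `CNC[C@@H]1CCN(c2cc3c(cc2F)c(=O)c(C(=O)O)cn3Cc2ccc(-n3cccn3)cc2)C1`: > 200000 nM, a limit of the assay rather than a number
compound 2 `O=C(O)c1cn(Cc2ccc(-c3ccccc3)cc2)c2cc(NC[C@@H]3CCNC3)c(F)cc2c1=O`: 104000 nM
compound 3 `NCCNc1cc2c(cc1F)c(=O)c(C(=O)O)cn2Cc1ccc(-c2ccccc2)cc1`: 72800 nM

Compound 2 holds the highest of the two actual numbers, with compound 3 nearest: a 1.4-fold lower number from compound 2 to compound 3 (0.15 log units; within the scatter), a change on the amine side only. Compound 1 sits at the limit of > 200000 nM in this assay, at which 1 of the 3 values shown sits.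

Compound 4 `O=C(O)c1cn(Cc2ccc(-n3cccn3)cc2)c2cc(NC[C@@H]3CCNC3)c(F)cc2c1=O` differs from compound 2 by 1H-pyrazol-1-yl in place of phenyl on an aromatic carbon. For the measured compounds named here, no measured step covers this exchange; the only step measured, a 1.4-fold lower number from compound 2 to compound 3 (0.15 log units; within the scatter), concerns the amine and stays within the scatter. Compound 1, which also carries the 1H-pyrazol-1-yl group, gave only a limit. Compound 4 is therefore expected to come out somewhat weaker than compound 2, a 1.5-fold higher number from compound 2 to compound 4 (0.19 log units; within the scatter), though this expectation rests on little. The estimate for compound 4 is 160000 nM, ranging from 60000 nM to 450000 nM.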

Compound 4, half-maximal inhibitory concentration: 200000 nM
Compound 4: the middle estimate sits 1.3-fold (0.10 log units) below what was measured; low and high end bracket the measured number.
By their numbers in this assay, from the lowest: compounds 3, 2 and 4 (each within the scatter of the next, the first and the last beyond it).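

In this assay, 1H-pyrazol-1-yl in place of phenyl gives a 1.9-fold higher number from compound 2 to compound 4 (0.28 log units; within the scatter), the first readable measure of this exchange on an aromatic carbon para to a large group. The two compounds cannot be told apart, so this exchange shows no clear effect on the number here. Compound 1 gives only a limit. The remaining step is a number no higher from compound 1 to compound 4 (the limit leaves the size open), and it cannot be read: the limit of > 200000 nM in this assay, at which 1 of the 4 values shown sits.

From the compounds shown here alone, it remains open whether a different group at this place, such as a morpholine ring or a dimethylamino group, would move the number beyond the scatter.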